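Tetrazolylphenyl thiazoles and a pyrimidinyl piperidine

The source may hold more compounds than are shown below. What is called first, only, known or untested is meant among the compounds shown, and "the series" means these compounds.

Compound 1 `CCc1cnc(N2CCC(c3nc(COc4ccc(/C=C5\CC(=O)NC5=O)cc4)cs3)CC2)nc1`: 182 nM
Compound 2 `CCOC(=O)CCc1cnc(N2CCC(c3nc(COc4ccc(-n5cnnn5)cc4)cs3)CC2)nc1`: "not determined" (no result reported)
Compound 3 `N=C(N)NC(=N)N1CCC(c2nc(COc3ccc(-n4cnnn4)cc3)cs2)CC1`: "not determined" (no result reported)

These three compounds were tested in a functional assay on cells for agonist activity at Glucose-dependent insulinotropic receptor (Homo sapiens), read by a luciferase reporter, with a stated time of 6 h; on this read-out lower numbers stand for an effect already at smaller amounts and higher numbers for an effect only at larger amounts of compound. Compound 1 gives 182 nM there. For compound 2 the result is "not determined" (no result reported) and for compound 3 it is "not determined" (no result reported), so compound 3 stands without a number, and one further compound, compound 2, also stands without one. Among the measured compounds shown here, no step between measured compounds can therefore be drawn.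

Compound 4 `CCc1cnc(N2CCC(c3nc(COc4ccc(-n5cnnn5)cc4)cs3)CC2)nc1` differs from compound 3 in one place: a group of 8 heavy atoms (6 carbon, 2 nitrogen; one six-membered aromatic ring with 2 hetero atoms) in place of a group of 6 heavy atoms (2 carbon, 4 nitrogen; no ring), on an amine nitrogen in a ring. For the measured compounds named here, the entering 5-ethylpyrimidin-2-yl group on the amine nitrogen in the ring is the one that compound 1 carries, and compound 1 is the only compound here with a number. Since compound 3 has no number, no direction or size of step from compound 3 to compound 4 can be given beyond the scatter. Compound 4 is expected to give about 300 nM, within 60 nM to 2000 nM, because compound 1 gives 182 nM in this assay and shares the same group on that nitrogen.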

Compound 4, half-maximal effective concentration: 87 nM
The estimate for compound 4 lay 3.4-fold (0.54 log units) above the measured number; the range from low to high includes it.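

In this assay, among the compounds shown here, the pair gives the first readable step at the aromatic carbon: a five-membered aromatic ring in place of the group with a five-membered non-aromatic ring gives a 2.1-fold lower number from compound 1 to compound 4 (0.32 log units; beyond the scatter). The 5-ethylpyrimidin-2-yl group is the same in both compounds, so the modest step belongs to that one place, and the smaller group of the two keeps the effect at this aromatic carbon. Nothing available here accounts for the step.

The steps involving compounds without a number cannot be read, so the part played by the group on the ring amine nitrogen stays unsettled. Also open, going by these compounds, is how a carboxylic acid or a primary amide on that aromatic carbon, or a propyl chain in place of the ethyl, would read.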